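A Chloro for Methoxy Swap on Weak Sulfonamides

The source may report more compounds than this note shows. Statements on the series, on what has been measured and on what is new or still open speak of the compounds shown alone.

Three sulfonamides share one core and differ only in the group on the sulfonyl sulfur. In an assay on cells for inhibition of HSP60/HSP10 (Homo sapiens), with a stated time of 60 min (a lower number here means a stronger inhibitor, a higher number a weaker inhibitor), compound 1 `O=S(=O)(Nc1ccc2oc(-c3ccccc3)nc2c1)c1cccs1` gives 90000 nM and compound 2 `O=S(=O)(Nc1ccc2oc(-c3ccccc3)nc2c1)c1cccc(O)c1` gives 76000 nM, and the step of a 1.2-fold lower number from compound 1 to compound 2 (0.07 log units; within the scatter) is small. Compound 3 `COc1ccc(S(=O)(=O)Nc2ccc3oc(-c4ccccc4)nc3c2)cc1` is known in this assay only as a limit, > 100000 nM. Both an at least 1.1-fold higher number from compound 1 to compound 3 (0.04 log units; that floor lies within the scatter) and an at least 1.3-fold higher number from compound 2 to compound 3 (0.11 log units; that floor lies within the scatter) end at compound 3, and neither floor rises beyond the scatter, so compound 3 stands at a limit rather than at a number; the evidence the limit of > 100000 nM in this assay, at which 1 of the 3 values shown sits, marks that edge. Compound 4 `O=S(=O)(Nc1ccc2oc(-c3ccccc3)nc2c1)c1ccc(Cl)cc1` differs from compound 3 by chloro in place of methoxy on an aromatic carbon. Within the data shown here, none of the measured steps changes a group on that ring in this way, and all three measured compounds are weak in this assay. For compound 4 no step beyond the scatter is expected, and the estimated step is an at least 1.1-fold lower number from compound 3 to compound 4 (0.04 log units; that floor lies within the scatter). Compound 4 is therefore expected to give about 90000 nM in this assay, with a range from 40000 nM to 200000 nM.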

Compound 4, half-maximal inhibitory concentration: > 100000 nM
Compound 4 ended at the assay's limit; the forecaster's own chance of this, stated with the estimate: 45%; middle value at least 1.1-fold (0.04 log units) from the limit.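

In this assay compound 4 gives > 100000 nM, which is a limit of the assay and not a number, so chloro in place of methoxy on this ring does not bring the series off that edge. Neither an at least 1.3-fold higher number from compound 2 to compound 4 (0.11 log units; that floor lies within the scatter) nor an at least 1.1-fold higher number from compound 1 to compound 4 (0.04 log units; that floor lies within the scatter) gets beyond the scatter, so the 4-chlorophenyl group is not separated from the 3-hydroxyphenyl or thiophen-2-yl groups. The step from compound 3 to compound 4 cannot be read, since both ends are limits, and the swap's size stays hidden: the limit of > 100000 nM in this assay, at which 2 of the 4 values shown sit.

On these data alone, what remains open is whether any group in this place would bring a compound into the readable range of this assay. An amine or a carboxylic acid on this ring could answer that, as a measured value rather than a limit would give the position a readable step.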